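The source may report more compounds than this note shows. Statements on the series, on what has been measured and on what is new or still open speak of the compounds shown alone.

Within the data shown here, in a functional assay on MCF7 cells (Homo sapiens) for cytotoxicity, read by MTT assay, with a stated time of 96 h (on this read-out higher numbers stand for weaker inhibition and lower numbers for stronger inhibition), compound 1 (`COc1cc(C(=O)c2cn(-c3ccccc3)cc2-c2ccc(N)cc2)cc(OC)c1OC`) gives 9 nM and stands lowest of the two numbers so far, while compound 2 (`COc1cc(C(=O)c2cn(-c3ccccc3)cc2-c2ccc([N+](=O)[O-])cc2)cc(OC)c1OC`) gives 590 nM with nitro in place of amino. That step (a 66-fold higher number from compound 1 to compound 2 (1.82 log units; beyond the scatter)) lies elsewhere than the change in compound 3 (`COc1cc(C(=O)c2cn(-c3cccc(C)c3)cc2-c2ccc(N)cc2)cc(OC)c1OC`), which is methyl in place of hydrogen on an aromatic carbon and reads methyl in place of hydrogen on an aromatic carbon. Among the measured compounds shown here, no measured step covers this place, so only a small upward shift in this assay is expected, possibly within the scatter. The estimated step (a 1.7-fold higher number from compound 1 to compound 3 (0.22 log units; within the scatter)) is modest. Compound 3 is expected at 15 nM in an estimated range from 4 nM to 60 nM on this read-out.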

Compound 3, half-maximal inhibitory concentration: 18 nM
Estimate against measurement, compound 3: 1.2-fold (0.08 log units) below; the range from low to high includes it.
By their numbers in this assay, from the lowest: compounds 1 and 3 (each within the scatter of the next); then compound 2.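

In this assay, among these compounds, the exchange of phenyl for 3-methylphenyl gives a 2.0-fold higher number from compound 1 to compound 3 (0.30 log units; within the scatter), so this place, on which the earlier compounds said nothing, takes a methyl without a step beyond the scatter. The exchange of amino for nitro, a 66-fold higher number from compound 1 to compound 2 (1.82 log units; beyond the scatter), lies at another place and remains the only large step among these compounds. Nothing available explains this tolerance of the methyl. On these data alone, whether an ethyl, a methoxy or a dimethylamino group at this place would read the same stays open, as does a methyl on another carbon of this ring.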